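Swapping Dimethylamino for Piperidinyl: Expected Clearance

The compounds below may be only part of what the source reports. "The series", "measured", "known", "first", "only" and "open" are said of these compounds alone.

Compound 1 `CN(C)c1cc(OCc2cc(F)c(Oc3ccc(Cl)c(C(F)(F)F)c3)c(F)c2)nc(=O)n1C` is the starting point. For the measured compounds named here, in an ADME assay on S9 fraction from liver (Rattus norvegicus, strain Wistar) for metabolic stability, tested at 0.1 uM (on this read-out lower numbers stand for slow clearance and higher numbers for fast clearance), compound 1 gives 82.8 mL/min/kg, the higher of the two numbers known here. Going by the values given here, compound 2 `CCOC(=O)CN(C)c1cc(OCc2cc(F)c(Oc3ccc(Cl)c(C(F)(F)F)c3)c(F)c2)nc(=O)n1C` gives 13.8 mL/min/kg, and the only measured step is a 6.0-fold lower number from compound 1 to compound 2 (0.78 log units; beyond the scatter). Compound 3 `Cn1c(N2CCCCC2)cc(OCc2cc(F)c(Oc3ccc(Cl)c(C(F)(F)F)c3)c(F)c2)nc1=O` differs from compound 1 by piperidin-1-yl in place of dimethylamino on an aromatic carbon. Among the compounds with values here, the measured step adds an ethoxycarbonyl and leaves the dimethylamino untouched, so no measured step speaks to this new change. Compound 3 is therefore expected to show a 1.0-fold lower number from compound 1 to compound 3 (0.01 log units; within the scatter), a step within the scatter. Compound 3 is estimated at 80 mL/min/kg, in the range 40 mL/min/kg to 160 mL/min/kg.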

Compound 3, clearance: 21.8 mL/min/kg
Compound 3: middle estimate off by 3.7-fold (0.56 log units), on the high side; the measured number lies below the stated range.
By their numbers in this assay, from the lowest: compounds 2 and 3 (each within the scatter of the next); then compound 1.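

In this assay, piperidin-1-yl in place of dimethylamino gives a 3.8-fold lower number from compound 1 to compound 3 (0.58 log units; beyond the scatter) without any ethoxycarbonyl being added, so changing the amine alone at this aromatic carbon can move the number. Piperidin-1-yl in place of ((ethoxycarbonyl)methyl)(methyl)amino gives a 1.6-fold higher number from compound 2 to compound 3 (0.20 log units; within the scatter) and so leaves these two quite different groups indistinguishable on this read-out. Nothing measured here explains either step.

Going by these compounds, it remains open whether a smaller ring such as pyrrolidin-1-yl, or a morpholin-4-yl ring, would behave like piperidin-1-yl. On these data alone, it is also open whether a carboxylic acid in place of the ethyl ester would match compound 2.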